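The source may hold more compounds than are shown below. What is called first, only, known or untested is meant among the compounds shown, and "the series" means these compounds.

Measured so far in a functional assay on CCRF-CEM cells (Homo sapiens) for antiproliferative activity, read by MTT assay, with a stated time of 96 h; a lower number here means a stronger inhibitor, a higher number a weaker inhibitor:
compound 1 `O=C1C2=C(C(=O)c3ncccc31)C1(CS2)NC(=O)N(c2ccc(Cl)cc2)C1=O`, 10 nM
compound 2 `O=C1C2=C(C(=O)c3ncccc31)C1(CS2)NC(=O)N(c2ccccc2)C1=O`, 10 nM
compound 3 `O=C1NN(c2ccc(Cl)cc2)C(=O)C2(CSC3=C2C(=O)c2ncccc2C3=O)N1`, 50 nM

Compound 1 and compound 2 share one core and differ by a single change, (hydrogen in place of chloro on an aromatic carbon). In this assay the step of no change at the digits printed from compound 1 to compound 2 (within the scatter) is flat, so the chloro on the aromatic ring contributes nothing that the measurement can resolve within this pair. Compound 3 carries the same 4-chlorophenyl group on a different core; the difference between the two cores is not broken down here. In this assay compound 3 gives 50 nM, the highest number of the three, and its gap to compound 1 and to compound 2 lies beyond the scatter in both cases, so the core of compound 3 reads as the weaker of the two cores with the chlorophenyl group in place.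

Compound 4 `O=C1NN(c2ccccc2)C(=O)C2(CSC3=C2C(=O)c2ncccc2C3=O)N1` is to compound 3 what compound 2 is to compound 1: the change is hydrogen in place of chloro on an aromatic carbon, with the place described in the same words for both pairs, so it is the same change moved to the core of compound 3. Among the compounds with values here, the only evidence on its effect is the flat step from compound 1 to compound 2, and the expected step from compound 3 to compound 4 is therefore no change at the digits printed from compound 3 to compound 4 (within the scatter), which rests on no change at the digits printed from compound 1 to compound 2 (within the scatter). Whether the second core carries this change in the same way is not tested by any of the three measured compounds, so the range is kept wide. Compound 4 is expected to give about 50 nM in this assay, estimated between 20 nM and 125 nM.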

Compound 4, half-maximal inhibitory concentration: 90 nM
Beside the measured number, compound 4's estimate is 1.8-fold (0.26 log units) below it; measured number inside the range.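

In this assay, going from 4-chlorophenyl to phenyl on the core of compound 3 gives a 1.8-fold higher number from compound 3 to compound 4 (0.26 log units; within the scatter), so on this core, as on the core of compound 1, the step does not rise out of the scatter. Set side by side, the two steps show that this change carries from one core to the other with no difference the measurement can resolve: the same change on two cores in this assay, no change at the digits printed (within the scatter) from compound 1 to compound 2 and a 1.8-fold higher number (0.26 log units; within the scatter) from compound 3 to compound 4, 1.8-fold (0.26 log units) apart, within the scatter of two such steps

This supports only a limited working statement: in these two pairs, in this single assay, the chloro can be exchanged for hydrogen without a resolved shift, but the data neither prove that the step is zero on either core nor show that it would stay flat on any further core or for any other change.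

The compounds shown hold only chloro or hydrogen on the aromatic carbon para to a large group, so it remains open how a methoxy group, an amine or a carboxylic acid at that place would read, and whether such a group would read alike on both cores. Also open is which part of the difference between the two cores accounts for the gap seen with the 4-chlorophenyl group in place.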